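Trimming One Chain: What to Expect for Compound 4

This account rests on a few compounds, and the source may have more. Where it says the series, first, only, none or still open, it means among the compounds named here.

In a functional assay on B16 cells (Mus musculus) for cytotoxicity, read by sulforhodamine B assay, with a stated time of 72 h (on this read-out lower numbers stand for stronger inhibition and higher numbers for weaker inhibition), compound 3 `OCC#CCSc1cnc2ccccc2c1SCC#CCO` gives 42.2 ug/mL, the highest of the three numbers, so it stands as the weakest inhibitor among them. Compound 1 `OCC#CCSc1cnc2ccccc2c1[Se]CC#CCBr` gives 4.6 ug/mL and compound 2 `OCC#CCSc1cnc2ccccc2c1SCC#CCBr` gives 4.9 ug/mL; the step of a 1.1-fold higher number from compound 1 to compound 2 (0.03 log units; within the scatter), while an 8.6-fold higher number from compound 2 to compound 3 (0.94 log units; beyond the scatter) and a 9.2-fold higher number from compound 1 to compound 3 (0.96 log units; beyond the scatter). Compound 4 `CSc1cnc2ccccc2c1SCC#CCO` differs from compound 3 by hydrogen in place of 3-hydroxyprop-1-yn-1-yl on a saturated chain carbon bound to a sulfur. Among the measured compounds shown here, none of the measured steps touches this chain; all three concern the other chain, where each change moved the number at most modestly. For the measured compounds named here, with no direct precedent, no step clearly beyond the scatter is expected, and the direction is uncertain. For compound 4 the estimate is 50 ug/mL, between 15 ug/mL and 150 ug/mL, meaning an expected 1.2-fold higher number from compound 3 to compound 4 (0.07 log units; within the scatter).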

Compound 4, concentration for 50% inhibition: 49.8 ug/mL
The estimate for compound 4 lay 1.0-fold (0.00 log units) above the measured number; the measured number falls inside the stated range.
By their numbers in this assay, from the lowest: compounds 1 and 2 (each within the scatter of the next); then compounds 3 and 4 (each within the scatter of the next).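

Among the compounds shown here, replacing 4-hydroxybut-2-yn-1-yl with methyl is the first change at this position, and in this assay it gives a 1.2-fold higher number from compound 3 to compound 4 (0.07 log units; within the scatter), so this chain can be cut back this far without a change beyond the scatter while the other chain ends in hydroxy. The change with a step beyond the scatter remains the one on the other chain, an 8.6-fold higher number from compound 2 to compound 3 (0.94 log units; beyond the scatter). No available evidence bears on the reason for this result.

As far as these compounds go, whether methyl would behave the same way alongside the bromo-ended chain of compound 2 remains open. So does the effect of an amine or a carboxylic acid at the end of this chain.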